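Flipping One Ring Stereocentre on a Hydroxamic Acid

This account rests on a few compounds, and the source may have more. Where it says the series, first, only, none or still open, it means among the compounds named here.

Compound 1 `O=C(NO)c1ccc(-c2cn([C@H]3C[C@@H](CO)N(Cc4ccccc4)C3)nn2)cc1` is the starting point. In an assay on Sf9 cells for inhibition of histone deacetylase 11 (Homo sapiens), read by fluorescence, tested at 0.5 uM (a higher number here means more inhibition at the concentration tested (going by the name of the read-out), a lower number less inhibition), compound 1 gives < 10%, which is a limit of the assay and not a number. Compound 2 `O=C(NO)c1ccc(-c2cn([C@H]3C[C@@H](C(=O)O)N(Cc4ccccc4)C3)nn2)cc1` carries a carboxy in place of hydroxymethyl on a saturated ring carbon. In this assay compound 2 gives < 10%, likewise a limit. The step that the two limits leave unreadable from compound 1 to compound 2 therefore cannot be read. Compound 3 `O=C(NO)c1ccc(-c2cn([C@H]3C[C@H](CO)N(Cc4ccccc4)C3)nn2)cc1` differs from compound 1 only in configuration: the two compounds have the same atoms and bonds and differ only in configuration as drawn: 1 of 2 stereo elements differ; a stereocentre at a saturated ring carbon is drawn S in compound 1 and R in compound 3. Going by the values given here, no measured step covers such a change, and the only evidence is the limit of < 10% in this assay, at which 2 of the 2 values shown sit. Compound 3 is accordingly expected to give 5%, within 0% to 15%, an expected step that the limit leaves unreadable from compound 1 to compound 3.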

Compound 3, a percentage reported as inhibition, at one concentration (the size of the read-out at that concentration, not a potency): 16%
The estimate for compound 3 lay 11 percentage points below the measured number, and the stated range ends below it.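

Going by these compounds alone, at this saturated ring carbon, the drawn configuration is the first change to lift a compound off the assay limit, with compound 3 giving a number. In this assay, the flip gives a number at least 6 percentage points higher from compound 1 to compound 3 (that floor lies within the scatter), so a real gain is not established. Any difference here can only come from one source: the fact that compounds 1 and 3 differ only in the configuration as drawn

Open, on these data alone, is whether the same flip would change anything for the carboxy group of compound 2. Also open, as far as these compounds go, is whether an amine or a longer chain on this ring carbon, drawn R, would give a step beyond the scatter.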